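Swapping methyl for chloro: what compound 4 might show

This account rests on a few compounds, and the source may have more. Where it says the series, first, only, none or still open, it means among the compounds named here.

For the measured compounds named here, in a toxicity assay on WI-38 cells (Homo sapiens) for inhibition, read by MTT assay, with a stated time of 72 h (a lower number here means a stronger inhibitor, a higher number a weaker inhibitor), compound 1 `Cc1ccc(N2CCCC2)c(C(=O)Nc2ccc(CNC(=O)OCc3cccnc3)cc2)c1` gives 40600 nM as the only true number so far. Compound 2 `O=C(NCc1ccc(NC(=O)c2ccc(F)cc2N2CCCC2)cc1)OCc1cccnc1` gives > 100000 nM as its reading, which is a limit of the assay and not a number. Compound 3 `Cc1cccc(C(=O)Nc2ccc(CNC(=O)OCc3cccnc3)cc2)c1N1CCCC1` also gives > 100000 nM as its reading, again a limit. Compound 1 is therefore the single measured point to work from.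

Compound 4 `O=C(NCc1ccc(NC(=O)c2cc(Cl)ccc2N2CCCC2)cc1)OCc1cccnc1` keeps the core of compound 1 and changes one place: chloro in place of methyl on an aromatic carbon, meta to a large group and para to a pyrrolidin-1-yl group (chloro in place of methyl on an aromatic carbon). Going by the values given here, no two measured compounds differ at just one place, so the data offer no direct guide to this swap. The expectation rests on compound 1 at 40600 nM as the anchor. No move beyond the usual scatter in this assay is expected in either direction, and the estimated step of a 1.1-fold higher number from compound 1 to compound 4 (0.04 log units; within the scatter) is small. A reading that reaches only a limit is also possible, given the limit of > 100000 nM in this assay, at which 2 of the 3 values shown sit, in so small a set. For compound 4 the estimate is 45000 nM with an expected range from 15000 nM to 100000 nM when it is measured.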

Compound 4, half-maximal inhibitory concentration: > 100000 nM
Compound 4 ended at the assay's limit (the forecaster's own chance of this, stated with the estimate: 30%); middle value at least 2.2-fold (0.34 log units) from the limit.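

For the compounds shown here, at this place on the aromatic ring, para to a pyrrolidin-1-yl group, the swap of methyl for chloro gives the first comparison in this assay between two compounds that differ in one place only, with an at least 2.4-fold higher number from compound 1 to compound 4 (0.39 log units; beyond the scatter). Compound 4 reads > 100000 nM, which is a limit of the assay and not a number, so the step has a known lower bound but no known full size. The methyl of compound 1 therefore goes with the only true number shown, and exchanging that single group for chloro is enough to carry the reading out of the range the assay can report, where most of the set now sits: the limit of > 100000 nM in this assay, at which 3 of the 4 values shown sit.

Going by these compounds, how far past the limit compound 4 really lies remains open, and this single pair cannot say whether the reading of compound 1 depends on methyl specifically or whether other groups at this place would serve as well. On these data alone, what an amine, a methoxy group or a carboxylic acid would read at this place also remains open, including whether any of them would give a lower number than compound 1 does.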